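The source may hold more compounds than are shown below. What is called first, only, known or untested is meant among the compounds shown, and "the series" means these compounds.

The measured compounds are:
compound 1, `COc1ccc(C2=C(c3cc(OC)c(OC)c(OC)c3)C(=O)CC2O[SiH2]C(C)(C)C)cc1`;
compound 2, `COc1ccc(C2=C(c3cc(OC)c(OC)c(OC)c3)CC(O)C2=O)cc1[N+](=O)[O-]`;
compound 3, `COc1ccc(C2=C(c3cc(OC)c(OC)c(OC)c3)C(=O)CC2O)cc1`.

In an ADME assay on L132 cells (Homo sapiens) for cytotoxicity, read by MTT assay, with a stated time of 72 h (a lower number here means a stronger inhibitor, a higher number a weaker inhibitor), compound 3 gives 10 ug/mL. For compound 1 this assay reports only a limit, > 100 ug/mL. For compound 2 this assay also reports only a limit, > 100 ug/mL.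

Compound 3 and compound 1 share a core and differ in a single place: a group of 5 heavy atoms (4 carbon, 1 silicon; no ring) in place of a hydrogen atom, on an oxygen on a saturated carbon. This change gives an at least 10-fold higher number from compound 3 to compound 1 (1.00 log units; beyond the scatter), a step whose size is set by the limit of > 100 ug/mL in this assay, at which 2 of the 3 values shown sit.

Compound 4, `COc1ccc(C2=C(c3cc(OC)c(OC)c(OC)c3)CC(O[SiH2]C(C)(C)C)C2=O)cc1[N+](=O)[O-]`, has not been measured. It differs from compound 2 by the same change, made at the same kind of place: a group of 5 heavy atoms (4 carbon, 1 silicon; no ring) in place of a hydrogen atom, on an oxygen on a saturated carbon. The difference between the core of compound 2 and the core of compound 3 is not broken down here.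

Compound 2 already sits at the limit of this assay. The step from compound 2 to compound 4 is therefore expected to be a step that the limit leaves unreadable from compound 2 to compound 4, with the earlier step only showing the direction. Compound 4 is estimated at 200 ug/mL, most likely reported once more as a limit, within 100 ug/mL to 400 ug/mL.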

Compound 4, half-maximal inhibitory concentration: > 100 ug/mL
Compound 4 ended at the assay's limit; the forecaster's own chance of this, stated with the estimate: 85%; the middle value does not contradict the limit.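

No step can be read from compound 2 to compound 4 in this assay, since both compounds end at a limit and not at a number: the limit of > 100 ug/mL in this assay, at which 3 of the 4 values shown sit.

The compounds shown leave open whether the same change on the core of compound 2 moves the number in the same direction as it does from compound 3 to compound 1.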